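Bromo for fluoro on the aryl thiosemicarbazone of compound 3

The compounds below may be only part of what the source reports. "The series", "measured", "known", "first", "only" and "open" are said of these compounds alone.

Compound 1 `CCCCCCNC(=S)N/N=C1\C(=O)Nc2ccc([N+](=O)[O-])cc21`: 25%
Compound 2 `Cc1cccc(NC(=S)N/N=C2\C(=O)Nc3ccc([N+](=O)[O-])cc32)c1`: 10%
Compound 3 `O=C1Nc2ccc([N+](=O)[O-])cc2/C1=N/NC(=S)Nc1ccc(F)cc1`: 5%

All three were measured in a functional assay on the whole organism for inhibition, with Lemna aequinoctialis as the target, tested at 10 ug/mL; on this read-out higher numbers stand for more inhibition of growth at the one concentration tested and lower numbers for less inhibition of growth. Compound 3 sits at the low end of the three, with a number 20 percentage points lower from compound 1 to compound 3 (beyond the scatter); against compound 2, however, a number 5 percentage points lower from compound 2 to compound 3 (within the scatter), so these two cannot be told apart. The substituent on the amide-type nitrogen is the only place the three differ: a number 15 percentage points lower from compound 1 to compound 2 (beyond the scatter) and a number 20 percentage points lower from compound 1 to compound 3 (beyond the scatter) both mark the move from hexyl to an aryl group, while the swap of one aryl for another, a number 5 percentage points lower from compound 2 to compound 3 (within the scatter), left the number where it was.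

Compound 4 `O=C1Nc2ccc([N+](=O)[O-])cc2/C1=N/NC(=S)Nc1ccc(Br)cc1` carries the change (bromo in place of fluoro on an aromatic carbon). Within the data shown here, no measured step exchanges one halogen for another, so the closest guide is the aryl-to-aryl step from compound 2 to compound 3, which stayed within the scatter. The expected step is therefore a number 3 percentage points higher from compound 3 to compound 4 (within the scatter), none beyond the scatter. Compound 4 is accordingly expected to give about 8% in this assay, within 0% to 25%.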

Compound 4, percent growth inhibition at one concentration: 10%
Compound 4: the middle estimate sits 2 percentage points below what was measured; measured number inside the range.
By their numbers in this assay, from the lowest: compounds 3, 2 and 4 (each within the scatter of the next); then compound 1.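

In this assay, among these compounds, the step of a number 5 percentage points higher from compound 3 to compound 4 (within the scatter) is the first exchange of one halogen for another on this aromatic carbon, and by this read-out fluoro and bromo cannot be told apart. The step of no change at the digits printed from compound 2 to compound 4 (within the scatter) leaves 4-bromophenyl indistinguishable from 3-methylphenyl, while the step of a number 15 percentage points lower from compound 1 to compound 4 (beyond the scatter) keeps it clearly apart from hexyl, so all three aryl groups shown now stand on the same side of that gap. Nothing measured here gives a reason for either result.

As far as these compounds go, whether a different kind of group on this ring carbon, such as an amine or a carboxylic acid, would shift the number remains open. So does whether a chain longer than hexyl on the amide-type nitrogen would differ from hexyl itself.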